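The compounds below may be only part of what the source reports. "The series", "measured", "known", "first", "only" and "open" are said of these compounds alone.

Measured compounds:
- compound 1, `Fc1ccc(-c2nc3cccnc3o2)cc1`: 27%
- compound 2, `c1ccc(-c2nc3cccnc3o2)cc1`: 55%

Both values come from a functional assay on the whole organism for inhibition, with Rattus norvegicus as the target, at a dose of 30 mg/kg; on this read-out higher numbers stand for more inhibition at the one dose given (going by the name of the read-out) and lower numbers for less inhibition. Compound 2 stands highest of the two numbers in this assay; its nearest neighbour is compound 1, and the step of a number 28 percentage points higher from compound 1 to compound 2 (beyond the scatter) lies beyond the scatter, the change being hydrogen in place of fluoro on an aromatic carbon.

Compound 3, `O=[N+]([O-])c1ccc(-c2nc3cccnc3o2)cc1`, has not been measured. Its difference from compound 2 is nitro in place of hydrogen on an aromatic carbon.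

Going by the values given here, only one measured step bears on this change: the step from compound 1 to compound 2, where a group on that same aromatic carbon gave way to hydrogen and the number rose by a modest amount beyond the scatter. Among the compounds with values here, compound 3 reverses the direction, putting a group onto that carbon again, though a different one, so a drop from compound 2 is expected, of size a number 20 percentage points lower from compound 2 to compound 3 (beyond the scatter), with wide uncertainty since nitro has no measured precedent here. Compound 3 is therefore expected to give about 35% in this assay, within a range of 10% to 60%.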

Compound 3, a percentage reported as inhibition, in the whole organism at one dose (the size of the read-out at that dose, not a potency): 5%
Compound 3: the middle estimate sits 30 percentage points above what was measured; measured number outside the range, below it.
By their numbers in this assay, from the lowest: compound 3; then compound 1; then compound 2.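

Nitro in place of hydrogen on this aromatic carbon gives in this assay the largest step seen so far, a number 50 percentage points lower from compound 2 to compound 3 (beyond the scatter) and so the fall on leaving hydrogen is not confined to fluoro. The two groups also differ from each other, with a number 22 percentage points lower from compound 1 to compound 3 (beyond the scatter) showing that at this carbon the number depends on which group is present and not only on hydrogen being replaced; in all the compounds shown, hydrogen gives the highest number. Nothing on hand accounts for either fall.

From the compounds shown here alone, whether any group at this carbon can match or exceed hydrogen remains open, as two groups cannot settle it, and an amine, a methoxy group or a carboxylic acid there would test this. Going by these compounds, the effect of changes elsewhere on the shared core also remains open.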